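The compounds below may be only part of what the source reports. "The series", "measured", "known", "first", "only" and "open" are said of these compounds alone.

Measured so far in an ADME assay on HepG2 2.2.15 cells (Homo sapiens) for cytotoxicity; on this read-out lower numbers stand for higher toxicity in this test and higher numbers for lower toxicity in this test:
compound 1 `CCOC(=O)CCCNc1ncc(C(Oc2ccc3cc(Br)ccc3c2)c2ccc(Cl)cc2)s1` — "not toxic" (no number reported)
compound 2 `COC(=O)CCCCNc1ncc(C(Oc2ccc3cc(Br)ccc3c2)c2ccc(Cl)cc2)s1` — "not toxic" (no number reported)
compound 3 `CCCCCC(=O)Nc1ncc(C(Oc2ccc3cc(Br)ccc3c2)c2ccc(Cl)cc2)s1` — > 50000 nM

All three compounds share one core and differ only in the group attached to the aminothiazole nitrogen. Compound 1 is recorded in this assay as "not toxic" (no number reported) and compound 2 as "not toxic" (no number reported); neither entry carries a number. For compound 3 the entry is a limit of the assay rather than a number, > 50000 nM. This is the limit of > 50000 nM in this assay, at which 1 of the 3 values shown sits, the only entry with a figure. Compound 3 therefore stands at the limit of this assay, with the other two entries giving no number that could be set against it. Within the data shown here, no pair of measured compounds differs in a single place, so no measured step exists.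

Compound 4 `O=C(Nc1ncc(C(Oc2ccc3cc(Br)ccc3c2)c2ccc(Cl)cc2)s1)c1ccccc1` is not yet measured. It differs from compound 3 by phenyl in place of pentyl on a carbonyl carbon. Among the measured compounds shown here, with no measured step to draw on, no shift beyond the scatter is expected in this assay. Compound 4 is estimated at 50000 nM, with a range from 20000 nM to 100000 nM. The expected step of a number no higher from compound 3 to compound 4 (the limit leaves the size open) is none beyond the scatter, and the result is most likely again reported as a limit.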

Compound 4, half-maximal cytotoxic concentration: "not toxic" (no number reported)
For compound 4 the study gives words and no number; there is nothing to compare the estimate with.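

No step from compound 3 to compound 4 can be read, because compound 4 carries words and no number, while compound 3 stands at a limit of the assay: the limit of > 50000 nM in this assay, at which 1 of the 4 values shown sits.

The compounds shown leave open whether any group on the aminothiazole nitrogen changes the result in this assay, as none of them gives an exact number.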